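The compounds below may be only part of what the source reports. "The series", "measured", "known", "first", "only" and "open" are said of these compounds alone.

Three compounds share one core and differ in the group carried on an aromatic carbon of the five-membered ring. Compound 1 `Cc1cc(C(=O)Nc2ccccc2)nn1Cc1cc(Cl)ccc1OCc1ccccc1` bears phenylcarbamoyl there. In an in vitro ADME assay on microsomes from liver (Rattus norvegicus) for metabolic stability (a higher number here means faster removal of the compound, a lower number slower removal), compound 1 gives 12 mL.min-1.g-1. Compound 2 `Cc1cc(C(=O)NCc2ccccc2)nn1Cc1cc(Cl)ccc1OCc1ccccc1` gives 15 mL.min-1.g-1, and compound 3 `Cc1cc(NC(=O)C2CCOCC2)nn1Cc1cc(Cl)ccc1OCc1ccccc1` gives 9.1 mL.min-1.g-1. Compound 1 stands second highest of the three numbers, yet all three lie close together: a 1.3-fold higher number from compound 1 to compound 2 (0.10 log units; within the scatter), and a 1.3-fold lower number from compound 1 to compound 3 (0.12 log units; within the scatter). The remaining pair is similar, a 1.6-fold lower number from compound 2 to compound 3 (0.22 log units; within the scatter).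

The unmeasured compound 4 `Cc1cc(NC(=O)OCC(C)C)nn1Cc1cc(Cl)ccc1OCc1ccccc1` differs from compound 1 at that same position: (isobutoxycarbonyl)amino in place of phenylcarbamoyl on an aromatic carbon. Within the data shown here, the measured step that comes closest to this exchange is the one from compound 1 to compound 3, where phenylcarbamoyl was likewise replaced by another group on the same aromatic carbon, and that step stayed within the scatter. The exchange of benzylcarbamoyl for the oxane group, from compound 2 to compound 3, was also within the scatter. Among the measured compounds shown here, nothing among the measured compounds shows a change at this position moving the number beyond the scatter, so the step that compound 4 is expected to show is estimated as a 1.1-fold lower number from compound 1 to compound 4 (0.04 log units; within the scatter). Compound 4 is therefore estimated at 11 mL.min-1.g-1, with a range from 5 mL.min-1.g-1 to 25 mL.min-1.g-1.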

Compound 4, intrinsic clearance in microsomes: 8.2 mL.min-1.g-1
Compound 4: the middle estimate sits 1.3-fold (0.13 log units) above what was measured, within the range that was stated.
By their numbers in this assay, from the lowest: compounds 4, 3, 1 and 2 (each within the scatter of the next).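

Compound 4 is the first of these compounds whose group at this position has no ring, since phenylcarbamoyl, benzylcarbamoyl and the oxane-bearing group all carry one, and in this assay the open (isobutoxycarbonyl)amino group still gives a 1.5-fold lower number from compound 1 to compound 4 (0.17 log units; within the scatter). The closest comparison keeps the nitrogen on the aromatic carbon and the carbonyl after it, and changes only what sits on that carbonyl: isobutoxy in place of oxan-4-yl gives a 1.1-fold lower number from compound 3 to compound 4 (0.05 log units; within the scatter), so this exchange also leaves the number inside the usual spread of repeated measurements. Even the widest step among the four compounds, a 1.8-fold lower number from compound 2 to compound 4 (0.26 log units; within the scatter), stays within that spread, so all four groups, ring-bearing or not, sit in one band and no order among them can be claimed.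

Still open, on these data alone, is whether this band holds for quite different groups at this position, such as an amine, a carboxylic acid or a longer chain in place of isobutoxy, and whether it would hold with the rest of the shared core changed. The data shown offer no explanation for why these four numbers stay so close together.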